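Phenyl for Cyclohexyl on a Carbamate Nitrogen

The source may hold more compounds than are shown below. What is called first, only, known or untested is meant among the compounds shown, and "the series" means these compounds.

Of the compounds shown here, three on one shared core have been measured in an ADME assay on HepG2 cells (Homo sapiens), read by MTT assay, with a stated time of 72 h, in the presence of a further agent that is not named here; on this read-out lower numbers stand for stronger inhibition and higher numbers for weaker inhibition. Compound 1 `O=C(Nc1ccccc1)Oc1ccc(Cl)cc1C(=O)Nc1ccc(F)cc1` gives 3250 nM. Compound 2 `O=C(NC1CCCCC1)Oc1ccc(Cl)cc1C(=O)Nc1ccc(F)cc1` gives 8600 nM, and compound 3 `O=C(NC1CCCCC1)Oc1ccc(Cl)cc1C(=O)Nc1ccc(Br)cc1` gives 9400 nM. Compound 2 and compound 3 differ in the core by bromo in place of fluoro on an aromatic carbon, a step of a 1.1-fold higher number from compound 2 to compound 3 (0.04 log units; within the scatter). Compound 1 arises from compound 2 by phenyl in place of cyclohexyl on an amide-type nitrogen, which gave a 2.6-fold lower number from compound 2 to compound 1 (0.42 log units; beyond the scatter). Compound 4 `O=C(Nc1ccccc1)Oc1ccc(Cl)cc1C(=O)Nc1ccc(Br)cc1` has not yet been measured; it differs from compound 3 by phenyl in place of cyclohexyl on an amide-type nitrogen, the same change at the same place. Because the earlier step read a 2.6-fold lower number from compound 2 to compound 1 (0.42 log units; beyond the scatter), a step of about a 2.6-fold lower number from compound 3 to compound 4 (0.42 log units; beyond the scatter) is expected from compound 3 to compound 4 in this assay, though it rests on one pair only. Compound 4 is therefore estimated at 3600 nM, between 1800 nM and 7200 nM.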

Compound 4, half-maximal inhibitory concentration: 5450 nM
Estimate against measurement, compound 4: 1.5-fold (0.18 log units) below; low and high end bracket the measured number.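

In this assay, phenyl in place of cyclohexyl on the amide-type nitrogen reads a 1.7-fold lower number from compound 3 to compound 4 (0.24 log units; within the scatter), and bromo in place of fluoro reads a 1.7-fold higher number from compound 1 to compound 4 (0.22 log units; within the scatter). The phenyl change gives a lower number on both cores, although only the earlier step lies beyond the scatter, and the two steps do not differ: the same change on two cores in this assay, a 2.6-fold lower number (0.42 log units; beyond the scatter) from compound 2 to compound 1 and a 1.7-fold lower number (0.24 log units; within the scatter) from compound 3 to compound 4, 1.5-fold (0.19 log units) apart, within the scatter of two such steps. The bromo change also carries over without a detectable difference, but two pairs of steps in one assay do not show that either change would hold on a further core: the same change on two cores in this assay, a 1.1-fold higher number (0.04 log units; within the scatter) from compound 2 to compound 3 and a 1.7-fold higher number (0.22 log units; within the scatter) from compound 1 to compound 4, 1.5-fold (0.19 log units) apart, within the scatter of two such steps.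

The compounds shown leave open how a benzyl group or a longer alkyl chain on that nitrogen would read. They also leave open whether a methoxy group or a nitrile in place of the bromo would follow these steps.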